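The source may hold more compounds than are shown below. What is called first, only, known or untested is meant among the compounds shown, and "the series" means these compounds.

Measured so far in an ADME assay on HeLa cells (Homo sapiens) for cytotoxicity, read by XTT assay, with a stated time of 3 days; on this read-out higher numbers stand for lower toxicity in this test and lower numbers for higher toxicity in this test:

Compound 1, `C1=C(/C=C/c2cccnc2)COc2ccccc21`, gives 75000 nM.
Compound 2, `Clc1ccc2c(c1)C=C(/C=C/c1cccnc1)CO2`, gives 37500 nM.
Compound 3, `O=c1c(/C=C/c2ccncc2)coc2ccccc12`, gives only a limit of the assay, > 100000 nM.

Compound 2 differs from compound 1 by chloro in place of hydrogen on an aromatic carbon, and the step was a 2.0-fold lower number from compound 1 to compound 2 (0.30 log units; within the scatter). How the core of compound 3 differs from that of compound 1 is not broken down here. Compound 4, `O=c1c(/C=C/c2ccncc2)coc2ccc(Cl)cc12`, carries the same change relative to compound 3: chloro in place of hydrogen on an aromatic carbon. Because compound 3 sits at the limit of > 100000 nM in this assay, at which 1 of the 3 values shown sits, no number is available as a starting point for compound 4. Resting on the small step seen in this assay from compound 1 to compound 2, compound 4 is expected to stay near the limit, with a number no higher from compound 3 to compound 4 (the limit leaves the size open). Compound 4 is estimated at 100000 nM, between 50000 nM and 300000 nM.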

Compound 4, half-maximal cytotoxic concentration: 150000 nM
For compound 4 the middle estimate is 1.5-fold (0.18 log units) below the measured one, within the range that was stated.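

No step can be read from compound 3 to compound 4, because the value of compound 3 is only a limit: the limit of > 100000 nM in this assay, at which 1 of the 4 values shown sits.

The compounds shown leave open what chloro in place of hydrogen on an aromatic carbon does to the number on the core of compound 3.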